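Cytotoxicity notes: from compound 2 to compound 3

This account rests on a few compounds, and the source may have more. Where it says the series, first, only, none or still open, it means among the compounds named here.

- compound 1 (`Cc1cc(-c2ccccc2)n2nc(C(=O)Nc3sc4c(c3C(N)=O)CCCC4)nc2n1`) gives > 250000 nM as a limit of the assay
- compound 2 (`Cc1cc(-c2ccccc2)nc2nc(C(=O)Nc3ccsc3C(N)=O)nn12`) gives 240000 nM as a measured number

Among the compounds with values here, in an ADME assay on MDCK cells (Canis lupus familiaris) for cytotoxicity, read by MTT assay, with a stated time of 48 h (on this read-out higher numbers stand for lower toxicity in this test and lower numbers for higher toxicity in this test), compound 2 holds the only true number so far, at 240000 nM on this scale. Compound 1 stands at > 250000 nM and this is a limit, not a number. The next compound to be tested is compound 3 (`Cc1cc(-c2ccccc2)nc2nc(C(=O)Nc3nc4ccccc4s3)nn12`), which keeps the shared core and changes one group: 1,3-benzothiazol-2-yl in place of 2-carbamoylthiophen-3-yl on an amide-type nitrogen. Within the data shown here, no measured step covers a change of this kind, so the expectation rests on very little. A modest move toward lower numbers in this assay is expected, about at the edge of the usual scatter, since compound 2 at 240000 nM has little room left upward. The estimated step of a 2.0-fold lower number from compound 2 to compound 3 (0.30 log units; within the scatter) is an expectation only. For compound 3 the expected value is 120000 nM with an estimated range from 40000 nM to 250000 nM and a report as a limit remains possible.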

Compound 3, half-maximal cytotoxic concentration: 233000 nM
Compound 3: middle estimate off by 1.9-fold (0.29 log units), on the low side; low and high end bracket the measured number.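

In this assay, within the data shown here, putting 1,3-benzothiazol-2-yl in place of 2-carbamoylthiophen-3-yl on the amide-type nitrogen, whose other neighbour is the carbonyl carbon, gives a 1.0-fold lower number from compound 2 to compound 3 (0.01 log units; within the scatter), the first step that can be read. A substituent with a hydrogen-bond donor and a single five-membered aromatic ring leaves, and one with no hydrogen-bond donor and an added six-membered aromatic ring of carbon only enters, yet the read-out does not separate the two compounds, so at this position the test shows no sensitivity to this exchange. Compound 1 stands at a limit and not at a number, which marks where the measurable range of the test ends: the limit of > 250000 nM in this assay, at which 1 of the 3 values shown sits.

Steps involving compound 1 cannot be read, and whether the flat result holds for other groups on this nitrogen remains unknown. An amine, a carboxylic acid or a longer alkyl chain in this place would show whether any substituent here can move the number clearly away from the top of the range.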